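Repeating a Methyl Addition on a Chlorophenyl Core

The source may report more compounds than this note shows. Statements on the series, on what has been measured and on what is new or still open speak of the compounds shown alone.

Three compounds were tested in a functional assay on HEK293 cells for antagonist activity at thromboxane A2 receptor (Homo sapiens), read by fluorescence and calcium flux; a lower number here means a stronger inhibitor, a higher number a weaker inhibitor. Compound 1 `Cc1ccccc1Oc1ccc(C#N)cc1S(=O)(=O)NC(=O)NC(C)C` gives 6130 nM. Compound 2 `Cc1ccccc1Oc1ccc(C#N)cc1S(=O)(=O)NC(=O)NC(C)(C)C` is set apart from compound 1 by methyl in place of hydrogen on a saturated chain carbon bound to an amide-type nitrogen and two saturated chain carbons. Compound 2 gives 1470 nM; that change made a 4.2-fold lower number from compound 1 to compound 2 (0.62 log units; beyond the scatter). Compound 3 `CC(C)NC(=O)NS(=O)(=O)c1cc(C#N)ccc1Oc1ccc(Cl)cc1` rests on a different core, differing from compound 1 by 4-chlorophenyl in place of 2-methylphenyl on an oxygen on an aromatic ring. Compound 3 gives 8490 nM; between the two cores there is a 1.4-fold higher number from compound 1 to compound 3 (0.14 log units; within the scatter), so they behave alike in this assay. Compound 4 `CC(C)(C)NC(=O)NS(=O)(=O)c1cc(C#N)ccc1Oc1ccc(Cl)cc1` awaits measurement. It applies to the core of compound 3 the same change seen before, (methyl in place of hydrogen on a saturated chain carbon bound to an amide-type nitrogen and two saturated chain carbons), at the very same place. A step of similar size is expected, a 3.9-fold lower number from compound 3 to compound 4 (0.59 log units; beyond the scatter), because the earlier one gave a 4.2-fold lower number from compound 1 to compound 2 (0.62 log units; beyond the scatter) on a core of near-identical activity. Compound 4 is therefore estimated to give about 2200 nM. For compound 4 the expected range runs from 900 nM to 5500 nM.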

Compound 4, half-maximal inhibitory concentration: 5270 nM
Beside the measured number, compound 4's estimate is 2.4-fold (0.38 log units) below it; measured number inside the range.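

In this assay, adding the methyl to the core of compound 3 gives a 1.6-fold lower number from compound 3 to compound 4 (0.21 log units; within the scatter), a step that cannot be told from noise, yet it cannot be told apart from the earlier step either: the same change on two cores in this assay, a 4.2-fold lower number (0.62 log units; beyond the scatter) from compound 1 to compound 2 and a 1.6-fold lower number (0.21 log units; within the scatter) from compound 3 to compound 4, 2.6-fold (0.41 log units) apart, within the scatter of two such steps. Putting 4-chlorophenyl in place of 2-methylphenyl on the tert-butyl compounds gives a 3.6-fold higher number from compound 2 to compound 4 (0.55 log units; beyond the scatter), and this step is likewise not separated from the same swap on the isopropyl compounds: the same change on two cores in this assay, a 1.4-fold higher number (0.14 log units; within the scatter) from compound 1 to compound 3 and a 3.6-fold higher number (0.55 log units; beyond the scatter) from compound 2 to compound 4, 2.6-fold (0.41 log units) apart, within the scatter of two such steps. The two cores thus show no measurable difference in how they take the change, but two pairs cannot prove that the change carries over unaltered.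

From the compounds shown here alone, a longer chain in place of the tert-butyl remains open on either core. So does a carboxylic acid in place of the nitrile.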